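Fluoro for Methoxy: What to Expect of Compound 3

The source may report more compounds than this note shows. Statements on the series, on what has been measured and on what is new or still open speak of the compounds shown alone.

Compound 1 `COc1ccc(CNC(=O)/C=C/c2coc3cc(O)ccc3c2=O)cc1`: in a functional assay on HeLa cells (Homo sapiens) for inhibition, read by MTT assay, with a stated time of 48 h (on this read-out lower numbers stand for stronger inhibition and higher numbers for weaker inhibition), compound 1 gives > 100000 nM, which is a limit of the assay, not a number.
Compound 2 `COc1ccc2c(=O)c(/C=C/C(=O)Nc3ccccc3)coc2c1`: in this assay compound 2 gives > 100000 nM, again a limit rather than a number.
Compound 3 `O=C(/C=C/c1coc2cc(O)ccc2c1=O)NCc1ccc(F)cc1`: not yet measured in this assay.

Compound 1 stands at the limit of > 100000 nM in this assay, at which 2 of the 2 values shown sit. Both values shown are limits, so neither compound can be placed above or below the other.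

Compound 3 differs from compound 1 by fluoro in place of methoxy on an aromatic carbon; cut one bond further out, the change reads 4-methoxyphenyl to 4-fluorophenyl. Going by the values given here, no step between measured compounds is known, so nothing measured tells how this change acts. With compound 1 already at the limit, no step beyond the scatter is expected in either direction. Compound 3 is therefore expected to sit at 100000 nM, estimated between 20000 nM and 500000 nM, most likely reported as a limit again, which is the step of a number no higher from compound 1 to compound 3 (the limit leaves the size open) expected here.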

Compound 3, half-maximal inhibitory concentration: > 100000 nM
Compound 3 gave a limit, no number; the forecaster's own chance of this, stated with the estimate: 85%; the middle value sits exactly at the limit.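

Compound 1 and compound 3 both end at a limit of the assay rather than a number, so no step can be read for fluoro in place of methoxy: the limit of > 100000 nM in this assay, at which 3 of the 3 values shown sit.

The compounds shown leave open how strongly any of them inhibits, and whether swapping methoxy for fluoro changes anything.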